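Opening the Hydroxypiperidine Ring on a Shared Kinase Inhibitor Core

The source may report more compounds than this note shows. Statements on the series, on what has been measured and on what is new or still open speak of the compounds shown alone.

Three measured compounds share one core. Compound 1 `OC1CCN(c2ncnc3[nH]cc(-c4cccc(Cl)c4)c23)CC1` gives 250 nM in an assay on HEK293T cells for displacement of a labelled ligand from serine/threonine-protein kinase 4 (Homo sapiens), read by NanoBRET, with a stated time of 2 h (a higher number here means a weaker inhibitor, a lower number a stronger inhibitor), the lowest of the three numbers. Compound 2 `CNC1CCN(c2ncnc3[nH]cc(-c4cccc(Cl)c4)c23)CC1` gives 408 nM, and compound 3 `Clc1cccc(-c2c[nH]c3ncnc(N4CCCCC4)c23)c1` gives 549 nM. The step of a 1.6-fold higher number from compound 1 to compound 2 (0.21 log units; within the scatter) lies within the scatter, whereas a 2.2-fold higher number from compound 1 to compound 3 (0.34 log units; beyond the scatter) is a modest loss. Compound 4 `CC(CO)CN(C)c1ncnc2[nH]cc(-c3cccc(Cl)c3)c12` differs from compound 1 in one place: a group of 7 heavy atoms (5 carbon, 1 nitrogen, 1 oxygen; no ring) in place of a group of 7 heavy atoms (5 carbon, 1 nitrogen, 1 oxygen; one six-membered non-aromatic ring with 1 hetero atom), on an aromatic carbon. Among the measured compounds shown here, no measured step opens a ring, so the change is only loosely anchored; the nearest guide is compound 3, which shows a modest loss when the hydroxy goes a 2.2-fold higher number from compound 1 to compound 3 (0.34 log units; beyond the scatter). Compound 4 is therefore expected to be somewhat weaker than compound 1, an estimated step of a 2.8-fold higher number from compound 1 to compound 4 (0.45 log units; beyond the scatter). The estimate for compound 4 is 700 nM, with a range from 250 nM to 2000 nM.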

Compound 4, half-maximal inhibitory concentration: 444 nM
Compound 4: middle estimate off by 1.6-fold (0.20 log units), on the high side; low and high end bracket the measured number.
By their numbers in this assay, from the lowest: compounds 1, 2, 4 and 3 (each within the scatter of the next, the first and the last beyond it).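

Replacing the 4-hydroxypiperidin-1-yl ring with an open chain that still carries a hydroxy group is tolerated at this aromatic carbon (a 1.8-fold higher number from compound 1 to compound 4 (0.25 log units; within the scatter)), so the closed ring is not required for binding here. The open chain also cannot be told apart from the other two ring compounds (a 1.1-fold higher number from compound 2 to compound 4 (0.04 log units; within the scatter); a 1.2-fold lower number from compound 3 to compound 4 (0.09 log units; within the scatter)). Nothing available explains this result. Going by these compounds, it remains open whether the chain's hydroxy matters, since a version carrying a methoxy or an amine in its place would test that. A longer chain could likewise show whether chain length affects the number.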